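One Aryl Swap on a Weak Amide Inhibitor

The source may hold more compounds than are shown below. What is called first, only, known or untested is meant among the compounds shown, and "the series" means these compounds.

compound 1 `COc1ccc2c(=O)c(/C=C/C(=O)Nc3ccc(Cl)cc3)coc2c1` — > 100000 nM
compound 2 `Cc1ccc(CNC(=O)/C=C/c2coc3cc(O)ccc3c2=O)cc1` — 24900 nM

In a functional assay (QGY7701 cells, Homo sapiens) for inhibition, read by MTT assay, with a stated time of 48 h (a higher number here means a weaker inhibitor, a lower number a stronger inhibitor), compound 1 reports only a limit, > 100000 nM, which places it at the weak end of the two values, the end marked by the limit of > 100000 nM in this assay, at which 1 of the 2 values shown sits. For the measured compounds named here, compound 2 is measured at 24900 nM in this assay, and no single step connects it to compound 1. Compound 3 `COc1ccc2c(=O)c(/C=C/C(=O)Nc3ccccc3C)coc2c1` differs from compound 1 by 2-methylphenyl in place of 4-chlorophenyl on an amide-type nitrogen. Going by the values given here, with no measured step to guide it, the change is expected to stay within the scatter, so compound 3 is estimated at 80000 nM, between 20000 nM and 250000 nM. That expected step is an at least 1.2-fold lower number from compound 1 to compound 3 (0.09 log units; that floor lies within the scatter).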

Compound 3, half-maximal inhibitory concentration: 22500 nM
Compound 3: the middle estimate sits 3.6-fold (0.55 log units) above what was measured, within the range that was stated.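

The aryl group on this amide-type nitrogen proves able to move the read-out: 2-methylphenyl in place of 4-chlorophenyl gives a step beyond the scatter (an at least 4.4-fold lower number from compound 1 to compound 3 (0.64 log units; beyond the scatter)). For the compounds shown here, this is the first measured step, since compound 2 connects to neither other compound by a single change. The step has only a floor and no exact size, because compound 1 stands at a limit: (the limit of > 100000 nM in this assay, at which 1 of the 3 values shown sits).

From the compounds shown here alone, how phenyl, 2-chlorophenyl or a pyridyl group would read on that nitrogen stays open. It therefore remains unclear whether losing the chlorine or gaining the methyl carries the step.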